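The source may hold more compounds than are shown below. What is called first, only, known or untested is meant among the compounds shown, and "the series" means these compounds.

Compound 3 `CN(C)c1ccc(/C=C(/SCc2ccc(F)cc2)C(=O)c2ccc(C(=O)O)cc2)cc1` is the reference point here. Among the compounds with values here, in a functional assay on DU-145 cells (Homo sapiens) for inhibition, read by trypan blue exclusion, with a stated time of 96 h (a lower number here means a stronger inhibitor of growth, a higher number a weaker inhibitor of growth), compound 3 gives 10000 nM, the lowest of the three numbers measured so far. Compound 1 `CN(C)c1ccc(/C=C(/SCc2ccc(F)cc2)C(=O)c2ccc(Cl)cc2)cc1` gives 50000 nM in this assay, and compound 2 `CN(C)c1ccc(/C=C(/SCc2ccc(Br)cc2)C(=O)c2ccc(C(=O)O)cc2)cc1` gives 50000 nM. Both measured steps point toward compound 3: a 5.0-fold lower number from compound 1 to compound 3 (0.70 log units; beyond the scatter), and a 5.0-fold lower number from compound 2 to compound 3 (0.70 log units; beyond the scatter), each beyond the scatter.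

Compound 4 `Nc1ccc(/C=C(/SCc2ccc(F)cc2)C(=O)c2ccc(C(=O)O)cc2)cc1[N+](=O)[O-]` differs from compound 3 at a third place: 4-amino-3-nitrophenyl in place of 4-(dimethylamino)phenyl on a double-bonded chain carbon bound to a double-bonded chain carbon. Neither measured step touches this part of the molecule, so neither bears directly on the change; they show only that single replacements elsewhere moved this assay by modest amounts. With no guide for this position, no step beyond the scatter is confidently expected, but the estimate leans toward a weaker inhibitor, because the two changes that did help are already present in compound 3 at 10000 nM. Compound 4 is therefore expected to give 20000 nM, within a range of 5000 nM to 50000 nM, an expected step of a 2.0-fold higher number from compound 3 to compound 4 (0.30 log units; within the scatter).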

Compound 4, concentration for 50% growth inhibition: 10000 nM
Estimate against measurement, compound 4: 2.0-fold (0.30 log units) above, and the stated range covers the measured number.
By their numbers in this assay, from the lowest: compounds 3 and 4 (each within the scatter of the next); then compounds 1 and 2 (each within the scatter of the next).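

In this assay, 4-amino-3-nitrophenyl in place of 4-(dimethylamino)phenyl on a double-bonded chain carbon bound to a double-bonded chain carbon gives no change at the digits printed from compound 3 to compound 4 (within the scatter). Within the data shown here, this is the first measured replacement at this place, and it shows that, on this background of carboxy and fluoro, a quite different set of groups on the aromatic ring leaves the number within the scatter, unlike the two single replacements made elsewhere in the molecule. No measurement shown here accounts for the two groups reading alike.

The compounds shown leave open whether an unsubstituted phenyl or a 4-methoxyphenyl at this place would also read alike in this assay. They also leave open whether the same replacement would hold with chloro in place of carboxy or with bromo in place of fluoro.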